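A few compounds are considered here, and "the series" means these few. Any claim that something is new, unique, unknown or untested is made for them only; others in the source may bear on it.

Measured compounds, inhibition of cell growth in a functional assay on CCRF-CEM cells (Homo sapiens) for inhibition, read by cell counting, with a stated time of 3 days; a higher number here means a weaker inhibitor, a lower number a stronger inhibitor:

- compound 1 `C=C(Br)C(=O)Nc1cccc(-c2cn3nc(Cc4ccccc4)sc3n2)c1`: 4200 nM
- compound 2 `C=C(Br)C(=O)Nc1cccc(-c2cn3nc(-c4cccc(OC)c4)sc3n2)c1`: 1200 nM

For the measured compounds named here, compound 2 gives the lower of the two numbers in this assay; the only other compound, compound 1, sits higher by the step of a 3.5-fold lower number from compound 1 to compound 2 (0.54 log units; beyond the scatter), which is beyond the scatter. Compound 3 `C=C(Br)C(=O)Nc1cccc(-c2cn3nc(-c4ccc(OC)c(OC)c4)sc3n2)c1` is not yet measured. It differs from compound 2 by methoxy in place of hydrogen on an aromatic carbon.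

Going by the values given here, no measured step bears directly on this change. Among the compounds with values here, the single step known, from compound 1 to compound 2, swaps a benzyl for a 3-methoxyphenyl and is a different kind of change, so it offers no guide to adding a second methoxy. With nothing pointing either way, the expectation is a step of about a 1.2-fold lower number from compound 2 to compound 3 (0.08 log units; within the scatter), that is, no change beyond the scatter. Compound 3 is therefore estimated at 1000 nM, with a range from 400 nM to 3000 nM.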

Compound 3, half-maximal inhibitory concentration: 380 nM
Compound 3: the middle estimate sits 2.6-fold (0.42 log units) above what was measured; measured number outside the range, below it.
By their numbers in this assay, from the lowest: compound 3; then compound 2; then compound 1.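

In this assay the ring carrying the 3-methoxyphenyl group still responds to substitution: a methoxy placed ortho to a methoxy group and para to a large group gives a 3.2-fold lower number from compound 2 to compound 3 (0.50 log units; beyond the scatter) and so lies beyond the scatter, which the benzyl swap alone could not show. Taken from the benzyl end, 3,4-dimethoxyphenyl in place of benzyl gives an 11-fold lower number from compound 1 to compound 3 (1.04 log units; beyond the scatter) as a large step, so the aryl substituent on the core remains the one place in this short series where the number has moved twice in the same direction. No measured evidence accounts for this gain.

Open, from the compounds shown here alone, is whether the gain is particular to methoxy or would also come with a fluorine, a hydroxyl, an ethoxy or a dimethylamino group at that place. Also open, going by these compounds, is whether the added methoxy would give a similar step without the methoxy already on the ring.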